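This account rests on a few compounds, and the source may have more. Where it says the series, first, only, none or still open, it means among the compounds named here.

Compound 1 `NC(=S)N1CCc2c(OCCCCCOc3ccc(Cl)cc3)cccc21` is the unsubstituted parent of the series. In an ADME assay on Huh-7 cells (Homo sapiens) for cytotoxicity (a lower number here means that less compound is tolerated, a higher number that more compound is tolerated), compound 1 gives > 50000 nM, which is a limit of the assay rather than a number (the limit of > 50000 nM in this assay, at which 1 of the 3 values shown sits). Compound 2 `O=C(NC(=S)N1CCc2c(OCCCCCOc3ccc(Cl)cc3)cccc21)c1ccc([N+](=O)[O-])cc1` gives 13600 nM in this assay. Compound 3 `COc1ccc(C(=O)NC(=S)N2CCc3c(OCCCCCOc4ccc(Cl)cc4)cccc32)cc1` gives 34400 nM in this assay. Compound 4 `O=C(NC(=S)N1CCc2c(OCCCCCOc3ccc(Cl)cc3)cccc21)c1cccnc1` carries the change ((pyridin-3-yl)carbonyl in place of hydrogen on an amide-type nitrogen). The two measured substitutions on the same nitrogen bear on it: an at least 3.6-fold lower number from compound 1 to compound 2 (0.56 log units; beyond the scatter) and an at least 1.4-fold lower number from compound 1 to compound 3 (0.16 log units; that floor lies within the scatter), with the step of a 2.5-fold higher number from compound 2 to compound 3 (0.40 log units; beyond the scatter) setting the two substituents apart. For the step to compound 4 a lowering of comparable size in this assay is therefore expected, falling between those two. Compound 4 is estimated at 25000 nM, within 10000 nM to 60000 nM. That estimate means an expected step of an at least 2.0-fold lower number from compound 1 to compound 4 (0.30 log units; that floor lies within the scatter).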

Compound 4, half-maximal cytotoxic concentration: 11100 nM
Beside the measured number, compound 4's estimate is 2.3-fold (0.35 log units) above it; the measured number falls inside the stated range.
By their numbers in this assay, from the lowest: compounds 4 and 2 (each within the scatter of the next); then compound 3. At a limit, above all of these: compound 1.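

In this assay, (pyridin-3-yl)carbonyl on the amide-type nitrogen gives a clear lowering, an at least 4.5-fold lower number from compound 1 to compound 4 (0.65 log units; beyond the scatter), and this step is only a floor, as compound 1 holds a limit of the assay. Changing the ring on the carbonyl carbon to pyridin-3-yl gives a 3.1-fold lower number from compound 3 to compound 4 (0.49 log units; beyond the scatter), but a 1.2-fold lower number from compound 2 to compound 4 (0.09 log units; within the scatter). Compound 4 and compound 2 therefore cannot be told apart here, while compound 3 stands apart from both.

On these data alone, whether acetyl, or an acyl group carrying an amine or a carboxylic acid, gives a similar lowering stays open. As far as these compounds go, the true value of compound 1 also stays open.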